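Oxazolyl Amide Next in a Series of Naphthyl Amides

The compounds below may be only part of what the source reports. "The series", "measured", "known", "first", "only" and "open" are said of these compounds alone.

Compound 2 `N#Cc1cccc(C(=O)Nc2c(C(O)(C(F)(F)F)C(F)(F)F)ccc3ccccc23)c1` gives 96% in a functional assay (Sus scrofa) with sulfonylurea receptors; K-ATP channels (Homo sapiens) as the target (a higher number here means a larger maximal response, a lower number a smaller maximal response), and stands level with compound 1 `COCC(=O)Nc1c(C(O)(C(F)(F)F)C(F)(F)F)ccc2ccccc12`, which gives 93%, the step of a number 3 percentage points higher from compound 1 to compound 2 (within the scatter) lying within the scatter. Compound 3 `O=C(Nc1c(C(O)(C(F)(F)F)C(F)(F)F)ccc2ccccc12)c1cnco1` differs from compound 2 by 1,3-oxazol-5-yl in place of 3-cyanophenyl on a carbonyl carbon. Among the compounds with values here, the only measured step, a number 3 percentage points higher from compound 1 to compound 2 (within the scatter), changed the same carbonyl carbon and stayed within the scatter, so in this assay no step beyond the scatter is expected here either. Compound 3 is estimated at 93%, with a range from 80% to 103%, which means an expected step of a number 3 percentage points lower from compound 2 to compound 3 (within the scatter).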

Compound 3, largest response reached (reported as efficacy), in percent of the reference or control that the assay uses: 97%
For compound 3 the middle estimate is 4 percentage points below the measured one; the range from low to high includes it.
By their numbers in this assay, from the lowest: compounds 1, 2 and 3 (each within the scatter of the next).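

In this assay the carbonyl carbon now carries a five-membered aromatic ring with 2 hetero atoms, and the read-out does not move beyond the scatter: 1,3-oxazol-5-yl in place of 3-cyanophenyl gives a number 1 percentage points higher from compound 2 to compound 3 (within the scatter) and in place of methoxymethyl gives a number 4 percentage points higher from compound 1 to compound 3 (within the scatter). Across these three compounds, the maximal response therefore does not separate a six-membered aromatic ring, a five-membered one and the methoxymethyl chain. Nothing shown explains this result.

On these data alone, whether an amine or a carboxylic acid on this carbonyl carbon would keep the response remains open, as does the effect of a longer chain there.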